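Solubility of an Amide Series: Estimating Compound 3

The compounds below may be only part of what the source reports. "The series", "measured", "known", "first", "only" and "open" are said of these compounds alone.

Measured so far:
compound 1, `COc1ccc2nc(C)cc(OCC(=O)Nc3cccc(C)c3)c2c1`, 193000 nM
compound 2, `COc1ccc2nc(C)cc(OCC(=O)Nc3c(C)cccc3C)c2c1`, 112000 nM

Compound 2 has the lowest of the two numbers in a physicochemical assay for solubility, in phosphate buffer, measured as kinetic solubility, with a stated time of 1 h, at pH 7.4 (on this read-out higher numbers stand for higher solubility and lower numbers for lower solubility), its nearest neighbour being compound 1, though a 1.7-fold lower number from compound 1 to compound 2 (0.24 log units; within the scatter), so the two values are not separated by more than the scatter. The unmeasured compound 3, `COc1ccc2nc(C)cc(OCC(=O)Nc3ccc(Br)c(C)c3)c2c1`, differs from compound 2 in one place: 4-bromo-3-methylphenyl in place of 2,6-dimethylphenyl on an amide-type nitrogen. For the measured compounds named here, only the step of a 1.7-fold lower number from compound 1 to compound 2 (0.24 log units; within the scatter) bears on this change, and it too exchanged one substituted phenyl for another on the same amide-type nitrogen, giving a movement that stayed within the scatter. On that single piece of evidence, another exchange of the aryl group on the amide-type nitrogen is expected to shift the number little, perhaps somewhat downward, and compound 3 is estimated at 70000 nM with a range from 20000 nM to 200000 nM, which means an expected step of a 1.6-fold lower number from compound 2 to compound 3 (0.20 log units; within the scatter).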

Compound 3, solubility: < 1000 nM
Compound 3 gave a limit, no number; the forecaster's own chance of this, stated with the estimate: 5%; middle value at least 70-fold (1.84 log units) away from the limit.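

In this assay, compound 3 gives a limit and not a number: the limit of < 1000 nM in this assay, at which 1 of the 3 values shown sits.

This shows that the aryl group on the amide-type nitrogen is not a place where exchanges always leave the read-out nearly unchanged: a 1.7-fold lower number from compound 1 to compound 2 (0.24 log units; within the scatter) was followed by an at least 110-fold lower number from compound 2 to compound 3 (2.04 log units; beyond the scatter), with 4-bromo-3-methylphenyl in place of 2,6-dimethylphenyl. The closer comparison has bromo in place of hydrogen on an aromatic carbon as its only difference, and it gives an at least 190-fold lower number from compound 1 to compound 3 (2.28 log units; beyond the scatter), so a single-atom exchange on this aryl group can accompany a large step.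

The compounds shown leave open whether a fluoro, a methoxy or an amine in place of the bromo would go with a similar step. They also leave open whether the same exchange on the 2,6-dimethylphenyl group of compound 2 would give a step of similar size.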